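Removing one methoxy from the benzyl end of compound 1

The source may hold more compounds than are shown below. What is called first, only, known or untested is meant among the compounds shown, and "the series" means these compounds.

The series shares a bis(trifluoromethyl)benzenesulfonamide linked through a three-carbon chain to a benzylamine, and it is followed in a functional assay on HT-29 cells (Homo sapiens) for inhibition, read by MTT assay, with a stated time of 72 h; on this read-out higher numbers stand for weaker inhibition of growth and lower numbers for stronger inhibition of growth. Compound 1 `COc1ccc(CNCCCNS(=O)(=O)c2cc(C(F)(F)F)cc(C(F)(F)F)c2)cc1OC` gives 2700 nM, the lowest number among the three measured compounds. Compound 2 `O=S(=O)(NCCCNCc1ccc(Cl)c(C(F)(F)F)c1)c1cc(C(F)(F)F)cc(C(F)(F)F)c1` gives 11000 nM and compound 3 `COc1ccccc1CNCCCNS(=O)(=O)c1cc(C(F)(F)F)cc(C(F)(F)F)c1` gives 12000 nM; the step of a 4.1-fold higher number from compound 1 to compound 2 (0.61 log units; beyond the scatter) and the step of a 4.4-fold higher number from compound 1 to compound 3 (0.65 log units; beyond the scatter) both show that replacing the 3,4-dimethoxyphenyl of compound 1 costs a modest amount of growth inhibition, while a 1.1-fold higher number from compound 2 to compound 3 (0.04 log units; within the scatter) leaves compound 2 and compound 3 indistinguishable.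

Compound 4 `COc1ccc(CNCCCNS(=O)(=O)c2cc(C(F)(F)F)cc(C(F)(F)F)c2)cc1` differs from compound 1 by hydrogen in place of methoxy on an aromatic carbon, which read one bond further out is 3,4-dimethoxyphenyl to 4-methoxyphenyl. For the measured compounds named here, no measured step removes a single methoxy from this ring; the closest evidence is compound 3, whose 2-methoxyphenyl keeps one methoxy and sits at 12000 nM. Both measured departures from the 3,4-dimethoxyphenyl weakened inhibition, so a weakening of a size between the scatter and those steps is expected, giving a 2.2-fold higher number from compound 1 to compound 4 (0.35 log units; beyond the scatter). Compound 4 is therefore estimated at 6000 nM in this assay, with a range from 2500 nM to 15000 nM.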

Compound 4, concentration for 50% growth inhibition: 2900 nM
For compound 4 the middle estimate is 2.1-fold (0.32 log units) above the measured one; low and high end bracket the measured number.
By their numbers in this assay, from the lowest: compounds 1 and 4 (each within the scatter of the next); then compounds 2 and 3 (each within the scatter of the next).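

In this assay, the 3,4-dimethoxyphenyl of compound 1 is not needed in full: the 4-methoxyphenyl of compound 4 reads the same within the scatter (a 1.1-fold higher number from compound 1 to compound 4 (0.03 log units; within the scatter)), so the methoxy removed here carries no measurable weight in growth inhibition. The earlier gap between compound 1 and compound 3 can therefore no longer be read as the loss of a methoxy, since a single methoxy is enough in the 4-methoxyphenyl but compound 3 with its 2-methoxyphenyl stands apart (a 4.1-fold lower number from compound 3 to compound 4 (0.62 log units; beyond the scatter)), which makes the place of the one remaining methoxy the variable that matters among these compounds. The 4-methoxyphenyl also keeps the same advantage over the 4-chloro-3-(trifluoromethyl)phenyl of compound 2 (a 3.8-fold lower number from compound 2 to compound 4 (0.58 log units; beyond the scatter)), so compound 1 and compound 4 now form the better pair and compound 2 and compound 3 the weaker pair.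

From the compounds shown here alone, whether the 4-methoxy itself contributes remains open, and an unsubstituted phenyl, a 4-hydroxyphenyl or a 3-methoxyphenyl at this end of the chain would test it. Nothing available explains the difference between the two pairs.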